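Bromo in place of acetyl at the end of compound 3

A few compounds are considered here, and "the series" means these few. Any claim that something is new, unique, unknown or untested is made for them only; others in the source may bear on it.

Compound 1 `COc1ccc(-c2cn3ccnc3c(-c3ccc4ncn(C5CCCCC5)c4c3)n2)cc1` gives 95.6% in a functional assay on RPMI-8226 cells (Homo sapiens) for inhibition, read by sulforhodamine B assay, with a stated time of 48 h, tested at 10 uM; a higher number here means more inhibition at the concentration tested (going by the name of the read-out), a lower number less inhibition.
Compound 2 `c1ccc2c(-c3cn4ccnc4c(-c4ccc5ncn(C6CCCCC6)c5c4)n3)cccc2c1` gives 22.9% in this assay.
Compound 3 `CC(=O)c1ccc(-c2cn3ccnc3c(-c3ccc4ncn(C5CCCCC5)c4c3)n2)cc1` gives 20.8% in this assay.

Compound 3 stands lowest of the three measured compounds, though its gap to compound 2 is within the scatter, so the two cannot be ordered. Only compound 1 stands clearly apart: the steps of a number 72.7 percentage points lower from compound 1 to compound 2 (beyond the scatter) and a number 74.8 percentage points lower from compound 1 to compound 3 (beyond the scatter) are both large, while the step of a number 2.1 percentage points lower from compound 2 to compound 3 (within the scatter) is small.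

Compound 4 `Brc1ccc(-c2cn3ccnc3c(-c3ccc4ncn(C5CCCCC5)c4c3)n2)cc1` differs from compound 3 in one place: bromo in place of acetyl on an aromatic carbon. Going by the values given here, no measured step covers this exchange. The steps from compound 1 show that replacing methoxy with either acetyl or a fused ring loses most of the inhibition; what bromo does at the same position is not shown by any measured pair, and bromo is neither of the groups already seen. The expectation for compound 4 in this assay therefore rests on little and must be wide.

Among the compounds with values here, for compound 4 a rise is expected, a number 19.2 percentage points higher from compound 3 to compound 4 (beyond the scatter), because the only large changes seen, a number 74.8 percentage points lower from compound 1 to compound 3 (beyond the scatter), run from a single high value down, and bromo need not share the outcome of acetyl. Compound 4 is estimated at 40%, with a range from 12% to 80%.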

Compound 4, a percentage reported as inhibition, at one concentration (the size of the read-out at that concentration, not a potency): 32.1%
Compound 4: middle estimate off by 7.9 percentage points, on the high side; the range from low to high includes it.
By their numbers in this assay, from the lowest: compounds 3, 2 and 4 (each within the scatter of the next, the first and the last beyond it); then compound 1.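

In this assay, the step of a number 11.3 percentage points higher from compound 3 to compound 4 (beyond the scatter) shows that the group at this position still matters among the replacements for methoxy: acetyl and bromo do not give the same reading, although the step is only modest. Bromo nevertheless falls far short of methoxy, with the large step of a number 63.5 percentage points lower from compound 1 to compound 4 (beyond the scatter) making it a third replacement, after acetyl and naphthalen-1-yl, that leaves the reading well under that of compound 1. The step of a number 9.2 percentage points higher from compound 2 to compound 4 (within the scatter) does not separate the 4-bromophenyl and naphthalen-1-yl compounds, and nothing available explains why methoxy stands apart from the other three groups.

As far as these compounds go, it remains open whether the high reading of compound 1 depends on the oxygen of the methoxy group, which a hydroxy group or an ethoxy group at the same place would help to test. An amine or a carboxylic acid there would show whether any other group can match methoxy, and a methoxy group moved to another carbon of the same ring would show how much its place on the ring counts.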